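Pyridin-3-yl Amide Variant of Compound 1

The source may hold more compounds than are shown below. What is called first, only, known or untested is meant among the compounds shown, and "the series" means these compounds.

Compound 1 `COCC(=O)Nc1c(C(O)(C(F)(F)F)C(F)(F)F)ccc2ccccc12` holds the lowest of the three maximal responses in a functional assay (Sus scrofa) with sulfonylurea receptors; K-ATP channels (Homo sapiens) as the target (a higher number here means a larger maximal response, a lower number a smaller maximal response), where compound 1 gives 93%. Compound 3 `O=C(Nc1c(C(O)(C(F)(F)F)C(F)(F)F)ccc2ccccc12)c1ccco1` stands nearest, giving 96%, and compound 2 `O=C(Nc1c(C(O)(C(F)(F)F)C(F)(F)F)ccc2ccccc12)c1cccc([N+](=O)[O-])c1` furthest, giving 99%; both gaps stay within the scatter, as a number 3 percentage points higher from compound 1 to compound 3 (within the scatter) and a number 6 percentage points higher from compound 1 to compound 2 (within the scatter) show. Compound 4 `O=C(Nc1c(C(O)(C(F)(F)F)C(F)(F)F)ccc2ccccc12)c1cccnc1` differs from compound 1 by pyridin-3-yl in place of methoxymethyl on a carbonyl carbon. Within the data shown here, the steps that bear on this are the two earlier replacements of methoxymethyl on the same carbonyl carbon, a number 6 percentage points higher from compound 1 to compound 2 (within the scatter) and a number 3 percentage points higher from compound 1 to compound 3 (within the scatter), neither beyond the scatter, and a number 3 percentage points lower from compound 2 to compound 3 (within the scatter) likewise. No step beyond the scatter is therefore expected in this assay, the estimated step being a number 3 percentage points higher from compound 1 to compound 4 (within the scatter). Compound 4 is thus expected to give 96%, with a range from 88% to 104%.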

Compound 4, largest response reached (reported as efficacy), in percent of the reference or control that the assay uses: 97%
The estimate for compound 4 lay 1 percentage points below the measured number, and the stated range covers the measured number.
By their numbers in this assay, from the lowest: compounds 1, 3, 4 and 2 (each within the scatter of the next).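

Replacing methoxymethyl with pyridin-3-yl on the carbonyl carbon stays within the scatter in this assay, with a number 4 percentage points higher from compound 1 to compound 4 (within the scatter) as the step. The two ring-to-ring steps do the same, with a number 1 percentage points higher from compound 3 to compound 4 (within the scatter) and a number 2 percentage points lower from compound 2 to compound 4 (within the scatter) as the readings, so a six-membered aromatic ring with a hetero atom joins the groups tolerated here, and all four compounds remain within the scatter of one another. Nothing available accounts for this flat response.

On these data alone, whether an amine, a carboxylic acid or a longer alkyl chain on this carbonyl carbon would shift the maximal response remains open. So does the effect of any change to the shared core, which all four compounds carry unaltered.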